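This account rests on a few compounds, and the source may have more. Where it says the series, first, only, none or still open, it means among the compounds named here.

Measured in a functional assay on SW480 cells (Homo sapiens) for antiproliferative activity, read by MTT assay, with a stated time of 48 h; a lower number here means a stronger inhibitor, a higher number a weaker inhibitor:
Compound 1 `CC(=O)OC/C1=C/C[C@](C)(CCC=C(C)C)/C=C/[C@@H](OC(=O)C=C(C)C)[C@](C)(O)/C=C/C1=O`: 2950 nM
Compound 2 `CC(C)=CCC[C@]1(C)/C=C/[C@@H](OC(=O)C=C(C)C)[C@](C)(O)/C=C/C(=O)/C(CN(C(C)C)C(C)C)=C\C1`: 750 nM
Compound 3 `COCOC/C1=C/C[C@](C)(CCC=C(C)C)/C=C/[C@@H](OC(=O)C=C(C)C)[C@](C)(O)/C=C/C1=O`: 3710 nM

Compound 3 sits level with compound 1, as a 1.3-fold higher number from compound 1 to compound 3 (0.10 log units; within the scatter) shows, and the two lie on the weaker side of compound 2. The gap on that side is a 4.9-fold higher number from compound 2 to compound 3 (0.69 log units; beyond the scatter).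

Compound 4 `CO/N=C/C1=C/C[C@](C)(CCC=C(C)C)/C=C/[C@@H](OC(=O)C=C(C)C)[C@](C)(O)/C=C/C1=O` has not yet been measured. The change leading to it is a group of 4 heavy atoms (2 carbon, 1 nitrogen, 1 oxygen; no ring) in place of a group of 5 heavy atoms (3 carbon, 2 oxygen; no ring), on a double-bonded ring carbon, on a double-bonded ring carbon, three ring bonds from the ring atom that bears a 4-methylpent-3-en-1-yl group.

Among the compounds with values here, no measured step makes this exchange directly. The closest guide is the swap of acetyl for methoxymethyl on an oxygen, which gave a 1.3-fold higher number from compound 1 to compound 3 (0.10 log units; within the scatter). Within the data shown here, the only steps beyond the scatter are a 3.9-fold lower number from compound 1 to compound 2 (0.59 log units; beyond the scatter) and a 4.9-fold higher number from compound 2 to compound 3 (0.69 log units; beyond the scatter). Both involve diisopropylamino, which compound 4 does not carry, so they say little about this change.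

In this assay, a value close to the pair of compound 1 and compound 3 is therefore expected, with no clear shift in either direction. The expected step is a 1.2-fold lower number from compound 3 to compound 4 (0.09 log units; within the scatter). The estimate for compound 4 is 3000 nM, with an expected range from 1200 nM to 7500 nM.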

Compound 4, half-maximal inhibitory concentration: 2630 nM
Compound 4: the middle estimate sits 1.1-fold (0.06 log units) above what was measured, and the stated range covers the measured number.
By their numbers in this assay, from the lowest: compound 2; then compounds 4, 1 and 3 (each within the scatter of the next).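

Read against (methoxymethoxy)methyl in this assay, the group of 4 heavy atoms, with its nitrogen and its double bond outside aromatic rings, gives a 1.4-fold lower number from compound 3 to compound 4 (0.15 log units; within the scatter) and, read against the acetoxy-bearing group, gives a 1.1-fold lower number from compound 1 to compound 4 (0.05 log units; within the scatter) and so leaves the number in place on this double-bonded ring carbon. A nitrogen in the group at this place is therefore not enough to match diisopropylamino: the exchange gives a 3.5-fold higher number from compound 2 to compound 4 (0.54 log units; beyond the scatter) and stands beyond the scatter. No measurement is at hand that would explain any of these steps.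

Going by these compounds, whether the lower number of compound 2 needs an amine nitrogen on the saturated chain carbon, or only a group of that size, stays open: a dimethylamino or morpholine group, or an all-carbon chain of like length, would separate the two. Also open, on these data alone, is how a free hydroxymethyl group or a carboxylic acid would compare at this place with the groups of compound 1, compound 3 and compound 4.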